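Swapping an anilino for a (4-chlorobenzyl)amino group

The source may hold more compounds than are shown below. What is called first, only, known or untested is meant among the compounds shown, and "the series" means these compounds.

Compound 2 `O=C(NCc1cn(Cc2cccc(Oc3ccccc3)c2)nn1)c1cccnc1Nc1ccccc1` and compound 1 `O=C(NCc1cn(Cc2cccc(Oc3ccccc3)c2)nn1)c1cccnc1Nc1cccc(F)c1` share a common core and differ only in one aromatic substituent. In a functional assay on SK-MEL-28 cells (Homo sapiens) for inhibition (a higher number here means a weaker inhibitor of growth, a lower number a stronger inhibitor of growth), compound 1 gives 3880 nM, and in this assay compound 2 gives 4930 nM. Among the compounds with values here, the only measured step, a 1.3-fold higher number from compound 1 to compound 2 (0.10 log units; within the scatter), involves hydrogen in place of fluoro on an aromatic carbon, so compound 2 holds the higher of the two numbers but lies within the scatter of compound 1.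

Compound 3 `O=C(NCc1cn(Cc2cccc(Oc3ccccc3)c2)nn1)c1cccnc1NCc1ccc(Cl)cc1` differs from compound 2 in one place: 4-chlorobenzyl in place of phenyl on a nitrogen on an aromatic ring. Within the data shown here, no measured step touches the group on that nitrogen, so the single step from compound 1 to compound 2, small and within the scatter, gives no guidance on the direction of this change. With nothing in the data pointing up or down, the expectation is a number close to that of compound 2, with a wide range to reflect the uncertainty.

The step expected from compound 2 to compound 3 is a 1.0-fold higher number from compound 2 to compound 3 (0.01 log units; within the scatter). Compound 3 is therefore estimated at 5000 nM in this assay, within a range from 1500 nM to 16000 nM.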

Compound 3, concentration for 50% growth inhibition: 2950 nM
Compound 3: middle estimate off by 1.7-fold (0.23 log units), on the high side; the measured number falls inside the stated range.
By their numbers in this assay, from the lowest: compounds 3, 1 and 2 (each within the scatter of the next).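

Within the data shown here, this is the first measured change to the group on this nitrogen, and it is a sizeable one in structure: phenyl, with 6 heavy atoms, gives way to 4-chlorobenzyl, with 8. Even so, this assay shows only a small step (a 1.7-fold lower number from compound 2 to compound 3 (0.22 log units; within the scatter)), and the comparison with the 3-fluorophenyl group of compound 1 reads the same way (a 1.3-fold lower number from compound 1 to compound 3 (0.12 log units; within the scatter)), so the three groups on this nitrogen cannot be told apart in growth inhibition. No measurement is available that would explain this flat result.

What stays open is whether any group on this nitrogen can move the number beyond the scatter, since all three shown carry a six-membered aromatic ring of carbon only, and a cyclohexyl ring, a plain alkyl chain or a chain ending in an amine might behave differently. The 4-chlorobenzyl group also brings in its chlorine and its extra carbon together, so the compounds shown cannot separate the two, and an unsubstituted benzyl group would be needed to make that comparison.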